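Chloro in place of fluoro on compound 2

The compounds below may be only part of what the source reports. "The series", "measured", "known", "first", "only" and "open" are said of these compounds alone.

- compound 1 `O=C(/C(=C\c1cccc(Cl)c1Cl)SCc1ccc(Cl)cc1)c1ccc(Br)cc1`: 10000 nM
- compound 2 `Cc1ccsc1/C=C(/SCc1ccc(F)cc1)C(=O)c1ccc(Br)cc1`: 50000 nM

In a functional assay on DU-145 cells (Homo sapiens) for inhibition, read by trypan blue exclusion, with a stated time of 96 h (on this read-out higher numbers stand for weaker inhibition of growth and lower numbers for stronger inhibition of growth), compound 2 gives 50000 nM and compound 1 gives 10000 nM. Compound 2 has the higher number of the two, and the gap lies beyond the scatter. Compound 3 `Cc1ccsc1/C=C(/SCc1ccc(Cl)cc1)C(=O)c1ccc(Br)cc1` carries chloro in place of fluoro on an aromatic carbon, para to a large group (chloro in place of fluoro on an aromatic carbon). Among the compounds with values here, no measured pair isolates this change. Compound 1 also bears 4-chlorobenzyl and gives 10000 nM, but it differs elsewhere too. In this assay a modest step toward stronger inhibition of growth, near the edge of the scatter, is expected: a 2.0-fold lower number from compound 2 to compound 3 (0.30 log units; within the scatter). For compound 3 the estimated value is 25000 nM, with an expected range of 9000 nM to 60000 nM.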

Compound 3, concentration for 50% growth inhibition: 25000 nM
The estimate for compound 3 equals the measured number at the digits printed; the range from low to high includes it.
By their numbers in this assay, from the lowest: compound 1; then compounds 3 and 2 (each within the scatter of the next).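

In this assay chloro in place of fluoro on an aromatic carbon, para to a large group, gives a 2.0-fold lower number from compound 2 to compound 3 (0.30 log units; within the scatter) and so leaves the number within the scatter at this position. With 4-chlorobenzyl held constant, 3-methylthiophen-2-yl in place of 2,3-dichlorophenyl gives a 2.5-fold higher number from compound 1 to compound 3 (0.40 log units; beyond the scatter) and this step, unlike the halogen change, lies beyond the scatter. Nothing on hand explains either step.

On these data alone, whether an amine or a methoxy group at this position would move the number beyond the scatter remains open. Also open, as far as these compounds go, is how a longer chain in place of the benzyl group would read in this assay.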